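The source may report more compounds than this note shows. Statements on the series, on what has been measured and on what is new or still open speak of the compounds shown alone.

Measured in a physicochemical assay for solubility; on this read-out lower numbers stand for lower solubility and higher numbers for higher solubility:
Compound 1 `CNC(=O)c1cc(C(=O)NC2CC2)cn(Cc2cccc(F)c2)c1=O`: >= 133 ug/mL (a limit of the assay)
Compound 2 `CNC(=O)c1cc(C(=O)NC2CC2)cn(Cc2cccc3[nH]ccc23)c1=O`: 78 ug/mL

Among the measured compounds shown here, compound 2 holds the only actual number so far. For compound 1, >= 133 ug/mL is a limit and not a number.

Compound 3 `CNC(=O)c1cc(C(=O)NC2CC2)cn(Cc2nccc3[nH]ccc23)c1=O` is the next compound to be read. The change is a group of 9 heavy atoms (7 carbon, 2 nitrogen; one five-membered aromatic ring with 1 hetero atom, one six-membered aromatic ring with 1 hetero atom) in place of a group of 9 heavy atoms (8 carbon, 1 nitrogen; one five-membered aromatic ring with 1 hetero atom, one six-membered aromatic ring of carbon only), on a saturated chain carbon bound to an aromatic nitrogen. The five-membered aromatic ring stays, while the six-membered aromatic ring of carbon only gives way to one with 1 hetero atom.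

For the measured compounds named here, the only measured step is an at least 1.7-fold lower number from compound 1 to compound 2 (0.23 log units; that floor lies within the scatter). It bears on this change only loosely: it occurs on the same saturated chain carbon bound to an aromatic nitrogen, but it involves a different pair of groups, and its floor lies within the scatter. Going by the values given here, no measured step covers the exchange in compound 3, so no step beyond the scatter is expected in this assay. The estimated change is a 1.3-fold higher number from compound 2 to compound 3 (0.11 log units; within the scatter). For compound 3 the estimate is 100 ug/mL. The expected range runs from 50 ug/mL to 190 ug/mL.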

Compound 3, solubility: 73 ug/mL
Compound 3: the middle estimate sits 1.4-fold (0.14 log units) above what was measured, within the range that was stated.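

In this assay, the six-membered aromatic ring with 1 hetero atom in place of the six-membered aromatic ring of carbon only, on a saturated chain carbon bound to an aromatic nitrogen, gives a 1.1-fold lower number from compound 2 to compound 3 (0.03 log units; within the scatter). Among the compounds shown here, this is the first fully numerical step at this position, and it shows that this exchange within the two-ring group, with the five-membered aromatic ring retained, produces no step beyond the scatter. The comparison with the 3-fluorophenyl group gives an at least 1.8-fold lower number from compound 1 to compound 3 (0.26 log units; that floor lies within the scatter), and the true size of this step cannot be read, since compound 1 carries a limit and not a number: the limit of >= 133 ug/mL in this assay, at which 1 of the 3 values shown sits.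

Going by these compounds, it remains open whether a group of another kind on the same saturated chain carbon, such as an amine, a carboxylic acid or a longer chain, would give a step beyond the scatter in this assay. The shared core is also identical in all three compounds, so the compounds shown say nothing about exchanges made anywhere else on it.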